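From Allyl to 2-(Dimethylamino)ethyl: One Side-Chain Step

A few compounds are considered here, and "the series" means these few. Any claim that something is new, unique, unknown or untested is made for them only; others in the source may bear on it.

In a functional assay on HCT-116 cells (Homo sapiens) for antiproliferative activity, read by sulforhodamine B assay, with a stated time of 72 h (a higher number here means a weaker inhibitor, a lower number a stronger inhibitor), compound 1 `CNC(=O)C[C@@H]1C[C@@H](c2ccc(Cl)c(Cl)c2)[C@H](NC(=O)c2cc(-c3c(Cl)cnn3C)c(Cl)o2)CN1` gives 450 nM, compound 2 `Cn1ncc(Cl)c1-c1cc(C(=O)N[C@@H]2CN[C@H](CC(N)=O)C[C@H]2c2ccc(Cl)c(Cl)c2)oc1Cl` gives 650 nM, and compound 3 `C=CC[C@@H]1C[C@@H](c2ccc(Cl)c(Cl)c2)[C@H](NC(=O)c2cc(-c3c(Cl)cnn3C)c(Cl)o2)CN1` gives 780 nM. These three numbers lie within the usual scatter of one another, so compound 3 cannot be ranked against the other two.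

Compound 4 `CN(C)CC[C@@H]1C[C@@H](c2ccc(Cl)c(Cl)c2)[C@H](NC(=O)c2cc(-c3c(Cl)cnn3C)c(Cl)o2)CN1` has not yet been measured. It differs from compound 3 by one change: (dimethylamino)methyl in place of vinyl on a saturated chain carbon bound to a saturated ring carbon.

Two measured steps alter this same side chain, and both are small: a 1.7-fold higher number from compound 1 to compound 3 (0.24 log units; within the scatter), and a 1.2-fold higher number from compound 2 to compound 3 (0.08 log units; within the scatter). A third, a 1.4-fold higher number from compound 1 to compound 2 (0.16 log units; within the scatter), is also small. None of these steps brings in a dimethylamino group, so they are only a rough guide, and the range must stay wide.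

No change beyond the scatter is expected, and the estimated step is a 1.3-fold lower number from compound 3 to compound 4 (0.11 log units; within the scatter). For compound 4 the expected value is 600 nM, with an estimated range of 230 nM to 1500 nM.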

Compound 4, half-maximal inhibitory concentration: 1710 nM
For compound 4 the middle estimate is 2.9-fold (0.45 log units) below the measured one; measured number above the stated range.
By their numbers in this assay, from the lowest: compounds 1, 2 and 3 (each within the scatter of the next); then compound 4.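

Among the compounds shown, 2-(dimethylamino)ethyl is the only group at this position whose number lies beyond the scatter of all the others in this assay (a 2.2-fold higher number from compound 3 to compound 4 (0.34 log units; beyond the scatter)). The number also moves the same way when the comparison starts from the two amide side chains (a 2.6-fold higher number from compound 2 to compound 4 (0.42 log units; beyond the scatter); a 3.8-fold higher number from compound 1 to compound 4 (0.58 log units; beyond the scatter)), so this position does respond to the group placed there, though all three steps are modest. Nothing measured here accounts for the higher number of compound 4.

The compounds shown cannot separate the effect of the dimethylamino group from that of the chain carrying it. A 2-aminoethyl group, a carboxylic acid or a longer chain ending in dimethylamino on the same ring carbon would show which of these matters.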